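A few compounds are considered here, and "the series" means these few. Any claim that something is new, unique, unknown or untested is made for them only; others in the source may bear on it.

Measured in an ADME assay on S9 fraction from liver (Mus musculus, strain ICR/CD-1) for metabolic stability, read by LC-MS, using NADPH, with a stated time of 5 min, tested at 2 uM; a lower number here means that the compound disappears faster, a higher number that the compound lasts longer:
- compound 1 `Cc1cc(Cl)cc(Cl)c1S(=O)(=O)N1CCC(N2CCC(C)CC2)CC1`: 0.12 h
- compound 2 `COc1ccccc1-c1cccc(S(=O)(=O)N2CCC(N3CCC(C)CC3)CC2)c1`: 0.25 h

Compound 2 stands highest of the two numbers in this assay; its nearest neighbour is compound 1, whose value is lower by a gap beyond the scatter. Going by the values given here, only two compounds have been measured and no pair among them differs in a single place, so no step has been characterised.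

Compound 3 `COc1ccc(-c2cccc(S(=O)(=O)N3CCC(N4CCC(C)CC4)CC3)c2)cc1` is not yet measured. It differs from compound 2 by 4-methoxyphenyl in place of 2-methoxyphenyl on an aromatic carbon. Among the compounds with values here, with no comparable step among the measured compounds, there is no basis for expecting a change beyond the scatter; the working expectation is a step of about a 1.1-fold lower number from compound 2 to compound 3 (0.06 log units; within the scatter), with no direction preferred. Compound 3 is accordingly estimated at 0.22 h in this assay, within a range from 0.1 h to 0.45 h, the range set wide because nothing measured speaks to this change.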

Compound 3, half-life: 2.4 h
Beside the measured number, compound 3's estimate is 11-fold (1.04 log units) below it; the whole stated range lies below it.
By their numbers in this assay, from the lowest: compound 1; then compound 2; then compound 3.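

In this assay, exchanging 2-methoxyphenyl for 4-methoxyphenyl on the aromatic carbon gives a 9.6-fold higher number from compound 2 to compound 3 (0.98 log units; beyond the scatter). The group that leaves and the group that enters have the same atoms and the same counted features, so the step shows that half-life in this series can depend strongly on where the methoxy group sits on the terminal phenyl ring, not only on which atoms are present. No measurement shown accounts for this difference.

The compounds shown do not separate an effect of losing 2-methoxyphenyl from an effect of gaining 4-methoxyphenyl, a question that a plain phenyl group would help settle. From the compounds shown here alone, it also remains open whether the higher number is specific to methoxy or would hold with 4-ethoxyphenyl or 4-fluorophenyl at this position.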